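Acetamido replacing fluoro on the aryl piperazine of compound 3

This account rests on a few compounds, and the source may have more. Where it says the series, first, only, none or still open, it means among the compounds named here.

Measured so far in a functional assay on HL-60 cells (Homo sapiens) for inhibition, read by MTT assay, with a stated time of 72 h; a lower number here means a stronger inhibitor, a higher number a weaker inhibitor:
- compound 1, `Cc1nc(-c2ccccc2)c(C(=O)N2CCN(c3ccc(Cl)c(Cl)c3)CC2)o1`: 124 nM
- compound 2, `Cc1nc(-c2ccccc2)c(C(=O)N2CCN(c3ccccc3)CC2)o1`: 39.1 nM
- compound 3, `Cc1nc(-c2ccccc2)c(C(=O)N2CCN(c3cccc(F)c3)CC2)o1`: 45 nM

Compound 3 stands second highest of the three numbers; its nearest neighbour is compound 2, with a 1.2-fold higher number from compound 2 to compound 3 (0.06 log units; within the scatter), and its furthest is compound 1, with a 2.8-fold lower number from compound 1 to compound 3 (0.44 log units; beyond the scatter). Compound 4, `CC(=O)Nc1cccc(N2CCN(C(=O)c3oc(C)nc3-c3ccccc3)CC2)c1`, has not been measured yet. The change from compound 3 is acetamido in place of fluoro on an aromatic carbon.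

Going by the values given here, no measured step exchanges a halogen for an acetamido group, so nothing bears directly on it. What the series shows is that the aryl ring tolerates small substitution without consequence (a 1.2-fold higher number from compound 2 to compound 3 (0.06 log units; within the scatter)), whereas the heavier 3,4-dichlorophenyl gives the highest number (a 3.2-fold lower number from compound 1 to compound 2 (0.50 log units; beyond the scatter)). Acetamido is larger than fluoro and brings a hydrogen-bond donor and acceptor, so a modest rise in the number, up to the size of the step from compound 1, is expected, with a wide range. Compound 4 is expected to give 85 nM, between 30 nM and 250 nM. That estimate means a 1.9-fold higher number from compound 3 to compound 4 (0.28 log units; within the scatter).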

Compound 4, half-maximal inhibitory concentration: 329 nM
For compound 4 the middle estimate is 3.9-fold (0.59 log units) below the measured one; measured number outside the range, above it.
By their numbers in this assay, from the lowest: compounds 2 and 3 (each within the scatter of the next); then compound 1; then compound 4.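

In this assay the aromatic carbon meta to a large group is not indifferent to what it carries: hydrogen and fluoro there lie within the scatter of each other, yet acetamido gives a 7.3-fold higher number from compound 3 to compound 4 (0.86 log units; beyond the scatter) and an 8.4-fold higher number from compound 2 to compound 4 (0.93 log units; beyond the scatter). The 3-acetamidophenyl group also goes past 3,4-dichlorophenyl, with a 2.7-fold higher number from compound 1 to compound 4 (0.42 log units; beyond the scatter), so the highest number in the series now belongs to compound 4 and its single substituent. No measurement at hand accounts for the rise.

Going by these compounds, whether the rise follows the amide hydrogen, the carbonyl or the greater count of heavy atoms stays open, and a free amine, a methoxy group or a carboxylic acid at this carbon would help separate these readings. Also open, on these data alone, is how acetamido fares on the other carbons of the ring.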